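A Third Stereocentre Flipped in a Cyclic Peptide

The source may hold more compounds than are shown below. What is called first, only, known or untested is meant among the compounds shown, and "the series" means these compounds.

Compound 1 `N=C(N)NCCC[C@@H]1NC(=O)CC(=O)N[C@@H](CC(=O)O)C(=O)N[C@@H](Cc2ccccc2)CNC1=O`: 520 nM
Compound 2 `N=C(N)NCCC[C@@H]1NC(=O)CC(=O)N[C@@H](CC(=O)O)C(=O)N[C@H](Cc2ccccc2)CNC1=O`: 24 nM
Compound 3 `N=C(N)NCCC[C@@H]1NC(=O)CC(=O)N[C@H](CC(=O)O)C(=O)N[C@@H](Cc2ccccc2)CNC1=O`: a limit, > 100000 nM

These three compounds share every atom and bond and differ only in how ring carbons are drawn. In an assay on K562 cells for inhibition of integrin alpha-5/beta-1 (Homo sapiens), with a stated time of 30 min (a higher number here means a weaker inhibitor, a lower number a stronger inhibitor), compound 1 gives 520 nM. Compound 2 gives 24 nM, and a 22-fold lower number from compound 1 to compound 2 (1.34 log units; beyond the scatter) is large. For compound 3 only a limit is known, > 100000 nM. Hence an at least 190-fold higher number from compound 1 to compound 3 (2.28 log units; beyond the scatter) and an at least 4100-fold higher number from compound 2 to compound 3 (3.61 log units; beyond the scatter) are lower bounds. Compound 4 `N=C(N)NCCC[C@H]1NC(=O)CC(=O)N[C@H](CC(=O)O)C(=O)N[C@@H](Cc2ccccc2)CNC1=O` takes one further step from compound 3: the two compounds have the same atoms and bonds; at least one stereo element is drawn with a configuration in one of them and without one in the other: 1 of 4 stereo elements differ; a stereocentre at a saturated ring carbon is drawn S in compound 3 and R in compound 4. Among the compounds with values here, no measured step turns that centre, so its effect is unknown; the centre that separates compound 1 from compound 3 stays as in compound 3. Compound 4 is therefore expected to remain weak, an at least 1.2-fold lower number from compound 3 to compound 4 (0.09 log units; that floor lies within the scatter), estimated at 80000 nM (range 5000 nM to 300000 nM).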

Compound 4, half-maximal inhibitory concentration: > 100000 nM
Compound 4 gave a limit, no number (the forecaster's own chance of this, stated with the estimate: 55%); middle value at least 1.2-fold (0.09 log units) from the limit.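

Compound 4 is a limit in this assay (> 100000 nM), so turning this ring carbon brings no binding back into the measurable range. The step from compound 3 cannot be read, since both of its ends are limits. Against the active compounds, the gaps remain lower bounds that span more than one centre (an at least 190-fold higher number from compound 1 to compound 4 (2.28 log units; beyond the scatter); an at least 4100-fold higher number from compound 2 to compound 4 (3.61 log units; beyond the scatter)).

As far as these compounds go, what this centre does on its own in a compound that still binds stays open. So does whether an amine in place of the guanidine would behave alike.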